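The source may hold more compounds than are shown below. What is called first, only, known or untested is meant among the compounds shown, and "the series" means these compounds.

Of the compounds shown here, three of the shared core have been measured in an assay on isolated protein for inhibition of DNA topoisomerase 1 (Homo sapiens), with a stated time of 30 min, tested at 20 uM; a lower number here means a weaker effect, a higher number a stronger effect of the compound at the concentration tested. Compound 1 `O=c1[nH]c(-c2cccc3ccccc23)nc2ccc(N3CCCCC3)cc12` gives 33.4%, compound 2 `Cc1ccc2c(=O)[nH]c(-c3ccccc3N(C)C)nc2c1` gives 5.3%, and compound 3 `Cc1ccc2c(=O)[nH]c(-c3cccc(OC(F)(F)F)c3)nc2c1` gives 0%. Compound 3 has the smallest of the three readings; its gap to compound 2 lies within the usual scatter, so no order between those two can be read, while compound 1 stands beyond the scatter from it. Compound 4 `COc1cccc(-c2nc3cc(C)ccc3c(=O)[nH]2)c1` has not yet been measured in this assay. It differs from compound 3 in one place: methyl in place of trifluoromethyl on an oxygen on an aromatic ring. Within the data shown here, no measured pair shows this change, so the expected step from compound 3 to compound 4 in this assay is small and in no set direction, a number 5 percentage points higher from compound 3 to compound 4 (within the scatter). Compound 4 is therefore estimated at 5%, in the range 0% to 20%.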

Compound 4, a percentage reported as inhibition, at one concentration (the size of the read-out at that concentration, not a potency): 80%
Estimate against measurement, compound 4: 75 percentage points below, and the stated range ends below it.
By their numbers in this assay, from the lowest: compounds 3 and 2 (each within the scatter of the next); then compound 1; then compound 4.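

In this assay, the change from trifluoromethoxy to methoxy on the aromatic ring is large, a number 80 percentage points higher from compound 3 to compound 4 (beyond the scatter), so the reading at this position depends strongly on the group carried by the oxygen. This is a single pair, and it shows the size of one exchange on the shared core, not a trend. Nothing available accounts for the step.

Going by these compounds, whether the oxygen itself is needed remains open, as does the effect of an ethoxy group, a longer chain on the oxygen, or an amine in its place. Also open, on these data alone, is whether the same exchange gives a step of this size with other groups elsewhere on the core.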